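This account rests on a few compounds, and the source may have more. Where it says the series, first, only, none or still open, it means among the compounds named here.

In a functional assay on RMS13 cells for antagonist activity at Urotensin-2 receptor (Homo sapiens), read by FLIPR and calcium flux, with a stated time of 1 h (on this read-out lower numbers stand for stronger inhibition and higher numbers for weaker inhibition), two compounds have been measured. Compound 1 `COc1ccc([C@@H](CCCN(C)S(=O)(=O)c2cccs2)N2Cc3c(cccc3N3CCN(C4CCC4)CC3)C2=O)cc1OC` gives 510 nM in this assay, and compound 2 `CCN1CCN(c2cccc3c2CN([C@H](CCCN(C)S(=O)(=O)c2cccs2)c2ccc(OC)c(OC)c2)C3=O)CC1` gives 88 nM in this assay. Among the measured compounds shown here, the one step between them, a 5.8-fold lower number from compound 1 to compound 2 (0.76 log units; beyond the scatter), is the only guide available. Compound 2 therefore stands with the lowest of the two numbers, and its nearest neighbour is compound 1 with a higher number by that same step.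

Compound 3 `COc1ccc([C@@H](CCCN(C)S(=O)(=O)c2cccs2)N2Cc3c(cccc3N3CCNCC3)C2=O)cc1OC` has not been measured in this assay. It differs from compound 2 in one place: hydrogen in place of ethyl on an amine nitrogen in a ring. For the measured compounds named here, the only measured step that bears on this change is the one from compound 1 to compound 2, in which the group on the amine nitrogen in the ring was made smaller and the number fell by a 5.8-fold lower number from compound 1 to compound 2 (0.76 log units; beyond the scatter). Going by the values given here, removing the ethyl altogether is a further shrinking of that group, but no measured pair shows what happens when the ring nitrogen carries only hydrogen, so the direction cannot be read from the data with confidence. He expects the step from compound 2 to compound 3 to be a 1.7-fold higher number from compound 2 to compound 3 (0.23 log units; within the scatter), with compound 3 estimated in this assay at 150 nM, in a range from 40 nM to 600 nM.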

Compound 3, half-maximal inhibitory concentration: 410 nM
Compound 3: middle estimate off by 2.7-fold (0.44 log units), on the low side; low and high end bracket the measured number.
By their numbers in this assay, from the lowest: compound 2; then compounds 3 and 1 (each within the scatter of the next).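

Within this assay, the earlier pair showed only that ethyl on the amine nitrogen of the six-membered ring gave a lower number than cyclobutyl, which left open whether a still smaller substituent would go further. Compound 3 answers this for the smallest case: going from 4-ethylpiperazin-1-yl to piperazin-1-yl gives a 4.7-fold higher number from compound 2 to compound 3 (0.67 log units; beyond the scatter) and so gives back about as much as the change from cyclobutyl to ethyl had gained, while hydrogen and cyclobutyl on this nitrogen stand level, with a 1.2-fold lower number from compound 1 to compound 3 (0.09 log units; within the scatter) lying within the scatter. Among these three compounds the number therefore does not follow the shrinking of the group in one direction, since ethyl alone stands apart from both the larger cyclobutyl and the bare hydrogen, and nothing measured here accounts for that.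

On these data alone, what remains open is how sharply this position tells groups apart, as methyl, n-propyl, isopropyl or cyclopropyl on the same nitrogen could show whether the low number belongs to ethyl alone or to a wider range of small alkyl groups. Also open, as far as these compounds go, is whether an acetyl group on this nitrogen, which would make it an amide, would keep the number of compound 2 at all.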